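The compounds below may be only part of what the source reports. "The series", "measured", "known", "first", "only" and "open" are said of these compounds alone.

In a functional assay on the whole organism with Rattus norvegicus as the target (on this read-out lower numbers stand for an effect already at smaller amounts and higher numbers for an effect only at larger amounts of compound), compound 1 `Nc1nc2ccc(OC(F)(F)C(F)(F)F)cc2s1` gives 2.5 mg/kg as its dose for half-maximal effect, and compound 2 `CCn1c(=N)sc2cc(OC(F)(F)F)ccc21` gives 5 mg/kg on the same read-out. These two numbers lie within the scatter of each other, so compound 2 stands level with compound 1 and the pair cannot be ranked.

Compound 3 `COC(=O)Cn1c(=N)sc2cc(OC(F)(F)F)ccc21` has not yet been measured in this assay and derives from compound 2 by a single change. That change is methoxycarbonyl in place of methyl on a saturated chain carbon bound to an aromatic nitrogen and reads in words as methoxycarbonyl in place of methyl on a saturated chain carbon bound to an aromatic nitrogen, so that ethyl becomes (methoxycarbonyl)methyl.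

Among the measured compounds shown here, no measured pair shows what such a change does on this read-out, and the expectation is therefore a loose one. A modest move toward larger doses is expected, only just beyond the scatter, starting from compound 2 at 5 mg/kg as the sole reference point. The expected step is a 2.4-fold higher number from compound 2 to compound 3 (0.38 log units; beyond the scatter) and it remains uncertain. For compound 3 the estimate is 12 mg/kg with an expected range from 4 mg/kg to 40 mg/kg in this assay overall.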

Compound 3, dose for half-maximal effect: > 10 mg/kg
Compound 3: a limit, no number; the forecaster's own chance of this, stated with the estimate: 10%; the middle value does not contradict the limit.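

In this assay, among the compounds shown here, compound 3 carries a limit and not a number, > 10 mg/kg, and this gives the first reading of any change on the saturated chain carbon bound to an aromatic nitrogen. Going from ethyl to (methoxycarbonyl)methyl amounts to an at least 2.0-fold higher number from compound 2 to compound 3 (0.30 log units; that floor lies within the scatter), so the step has only a floor and neither establishes nor excludes a real separation between the two compounds. What it adds is one-sided: methoxycarbonyl in place of methyl does not lead to a lower number than compound 2 shows, while the true size of the step stays unknown, and the only fixed point is this: the limit of > 10 mg/kg in this assay, at which 1 of the 3 values shown sits.

The compounds shown leave open whether this reading goes with the ester as such or with the chain carrying anything larger than methyl; a propyl chain, a carboxylic acid or a primary amide at the same place would bear on that question. They also leave open whether a group such as methoxy or hydroxyl on this chain would give a number that can be read rather than a limit.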